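Trimming a Benzyl to a Phenyl on the Amide Nitrogen

The compounds below may be only part of what the source reports. "The series", "measured", "known", "first", "only" and "open" are said of these compounds alone.

Of the compounds shown here, three built on one shared core have been measured in an assay on CHO cells for displacement of a labelled ligand from adenosine receptor A1 (Homo sapiens), tested at 10 uM; a lower number here means less inhibition, a higher number more inhibition at the concentration tested (going by the name of the read-out). Compound 1 `CC(=O)Nc1nn(-c2ccccc2)c(=O)c2ccccc12` gives 52%. Compound 2 `COc1ccc(NC(=O)Nc2nn(-c3ccccc3)c(=O)c3ccccc23)cc1` gives 4%, and compound 3 `O=C(NCc1ccccc1)Nc1nn(-c2ccccc2)c(=O)c2ccccc12` gives 20%. Compound 3 thus stands second of the three: a number 32 percentage points lower from compound 1 to compound 3 (beyond the scatter), while a number 16 percentage points higher from compound 2 to compound 3 (beyond the scatter). Compound 4 `O=C(Nc1ccccc1)Nc1nn(-c2ccccc2)c(=O)c2ccccc12` differs from compound 3 in a single place: phenyl in place of benzyl on an amide-type nitrogen. Among the measured compounds shown here, the measured step that bears most on this change is a number 16 percentage points higher from compound 2 to compound 3 (beyond the scatter), in which a benzyl took the place of a ring bound directly to the amide-type nitrogen; compound 4 goes back toward such a directly bound ring, though compound 2 carries 4-methoxyphenyl and compound 4 plain phenyl, so no measured step matches it exactly. On that basis a downward step of similar size is expected. Compound 4 is therefore expected to give about 8% in this assay, within 0% to 22%, which means an expected a number 12 percentage points lower from compound 3 to compound 4 (beyond the scatter).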

Compound 4, a percentage reported as inhibition, at one concentration (the size of the read-out at that concentration, not a potency): 44%
Estimate against measurement, compound 4: 36 percentage points below, and the stated range ends below it.
By their numbers in this assay, from the lowest: compound 2; then compound 3; then compounds 4 and 1 (each within the scatter of the next).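

In this assay phenyl in place of benzyl on the amide-type nitrogen gives a number 24 percentage points higher from compound 3 to compound 4 (beyond the scatter) and so shows that trimming this one carbon is no minor change at this position. Taking the methoxy off the aromatic ring gives a number 40 percentage points higher from compound 2 to compound 4 (beyond the scatter) and so shows that a ring bound directly to this nitrogen does not by itself go with a low number. Anilino in place of methyl on the carbonyl carbon gives a number 8 percentage points lower from compound 1 to compound 4 (within the scatter) and thus, unlike benzylamino and (4-methoxyphenyl)amino, does not separate from methyl.

Nothing shown here explains why the numbers move this way. Still open, from the compounds shown here alone, is whether a chlorine atom or a methyl on the phenyl ring, or a longer chain such as 2-phenylethyl on the amide-type nitrogen, would keep the number of compound 4.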